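Replacing fluoro with methoxy in compound 3

A few compounds are considered here, and "the series" means these few. Any claim that something is new, unique, unknown or untested is made for them only; others in the source may bear on it.

Of the compounds shown here, three sharing one core have been measured in a functional assay on MCF7 cells (Homo sapiens) for antiproliferative activity, read by MTT assay, with a stated time of 48 h; a higher number here means a weaker inhibitor, a lower number a stronger inhibitor. Compound 1 `N=C(N)N/N=C(/C=C/c1ccc(Br)cc1)c1ccccc1` gives 250 nM. Compound 2 `N=C(N)N/N=C(/C=C/c1cccc(F)c1)c1ccccc1` gives 16000 nM. Compound 3 `N=C(N)N/N=C(/C=C/c1ccccc1F)c1ccccc1` gives 3900 nM, the middle of the three numbers.

The next compound is compound 4 `COc1ccccc1/C=C/C(=N/NC(=N)N)c1ccccc1`, which carries methoxy in place of fluoro on an aromatic carbon, ortho to a large group: methoxy in place of fluoro on an aromatic carbon.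

Going by the values given here, no measured step makes this exchange. The closest evidence is a 4.1-fold lower number from compound 2 to compound 3 (0.61 log units; beyond the scatter), a modest step with 2-fluorophenyl in place of 3-fluorophenyl. Two larger steps replace 4-bromophenyl: a 64-fold higher number from compound 1 to compound 2 (1.81 log units; beyond the scatter) and a 16-fold higher number from compound 1 to compound 3 (1.19 log units; beyond the scatter). Together they show that, among these three compounds, changes to this aryl group can shift the number considerably. None of them, however, exchanges fluoro for another group at the same place, so the data give no direction for the change. The expected result in this assay is therefore no step beyond the scatter, and the expected change is a 1.3-fold lower number from compound 3 to compound 4 (0.11 log units; within the scatter). The large step seen with a 16-fold higher number from compound 1 to compound 3 (1.19 log units; beyond the scatter) nevertheless calls for a wide range. For compound 4 the estimated value is 3000 nM, with an expected range from 800 nM to 12000 nM.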

Compound 4, half-maximal inhibitory concentration: 7200 nM
For compound 4 the middle estimate is 2.4-fold (0.38 log units) below the measured one; measured number inside the range.
By their numbers in this assay, from the lowest: compound 1; then compounds 3 and 4 (each within the scatter of the next); then compound 2.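

In this assay, the exchange of fluoro for methoxy on this aromatic carbon, ortho to a large group, gives a 1.8-fold higher number from compound 3 to compound 4 (0.27 log units; within the scatter). Going by these compounds alone, this is the first step that replaces the fluoro itself rather than the whole substituted phenyl group, and it shows that this place accepts methoxy, with its 2 heavy atoms and 1 hydrogen-bond acceptor, in place of the single fluorine without a change that can be told from the scatter. No measurement at hand explains this result.

The compounds shown leave open whether the same holds for other groups at this carbon, such as a hydroxyl, an amine, a carboxylic acid or a longer chain such as ethoxy. Going by these compounds, they also leave open how methoxy would fare in the place of the bromine of the 4-bromophenyl group of compound 1, which gives 250 nM, the lowest number in the set, so it remains unknown whether methoxy there would keep a number of that order.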